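Replacing the 3-chloro-4-iodophenyl group of compound 2

A few compounds are considered here, and "the series" means these few. Any claim that something is new, unique, unknown or untested is made for them only; others in the source may bear on it.

In a functional assay on cells (leukaemia cell line, Homo sapiens) for inhibition, read by sulforhodamine B assay, with a stated time of 48 h (a lower number here means a stronger inhibitor of growth, a higher number a weaker inhibitor of growth), compound 1 `O=S(=O)(Nc1ccccc1Cl)c1ccc(-c2cnc(C3CC3)o2)cc1` gives 49700 nM and compound 2 `O=S(=O)(Nc1ccc(I)c(Cl)c1)c1ccc(-c2cnc(C3CC3)o2)cc1` gives 19600 nM in the same read-out, the lower of the two numbers. For the measured compounds named here, the one measured step shows a 2.5-fold lower number from compound 1 to compound 2 (0.40 log units; beyond the scatter) with 3-chloro-4-iodophenyl in place of 2-chlorophenyl on a sulfonamide nitrogen, and it is modest. Compound 3 `Cc1cc(Cl)cc(NS(=O)(=O)c2ccc(-c3cnc(C4CC4)o3)cc2)c1` carries 3-chloro-5-methylphenyl in place of 3-chloro-4-iodophenyl on a sulfonamide nitrogen. The measured step involves the same nitrogen but a different pair of groups, so it is only a loose guide. Going by the values given here, with a 2.5-fold lower number from compound 1 to compound 2 (0.40 log units; beyond the scatter) as the sole evidence, a small move to a higher number in this assay is expected, possibly no larger than the scatter. The expected change is a 1.4-fold higher number from compound 2 to compound 3 (0.15 log units; within the scatter) on this evidence. Compound 3 is estimated at 28000 nM with an expected range from 11000 nM to 60000 nM in this read-out.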

Compound 3, concentration for total growth inhibition: 7040 nM
Compound 3: middle estimate off by 4.0-fold (0.60 log units), on the high side, and the stated range ends above it.
By their numbers in this assay, from the lowest: compound 3; then compound 2; then compound 1.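

In this assay the change to 3-chloro-5-methylphenyl on a sulfonamide nitrogen gives a 2.8-fold lower number from compound 2 to compound 3 (0.44 log units; beyond the scatter) and shows that the iodine of the 3-chloro-4-iodophenyl group is not required for the lower number at this position. Measured against the 2-chlorophenyl group, the same change gives a 7.1-fold lower number from compound 1 to compound 3 (0.85 log units; beyond the scatter) and is the largest step among the three compounds, so this nitrogen's aryl group can still move the number beyond the scatter. Nothing available accounts for these differences. Because the step from compound 2 to compound 3 swaps iodine for methyl and also changes the substituent's place on the ring, the compounds shown do not separate these two changes. They also leave open whether the chlorine is needed, and how a methoxy, an amine or a carboxylic acid would fare in place of the methyl.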